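The source may hold more compounds than are shown below. What is called first, only, known or untested is meant among the compounds shown, and "the series" means these compounds.

Of the compounds shown here, three have so far been measured in an assay on isolated protein for displacement of a labelled ligand from metabotropic glutamate receptor 5 (Homo sapiens), with a stated time of 60 min, tested at 1 uM; a higher number here means more inhibition at the concentration tested (going by the name of the read-out), a lower number less inhibition. Compound 1 `CC1CCN(c2c(S(=O)(=O)c3ccc(F)c(Cl)c3)cnc3cc(Cl)ccc23)CC1` gives 94%, compound 2 `CCN1CCN(c2c(S(=O)(=O)c3ccccc3)cnc3ccccc23)CC1` gives 1.7%, and compound 3 `O=S(=O)(c1ccccc1)c1cnc2ccccc2c1N1CCCC1` gives 7.1%. Compound 3 thus holds the second highest of the three numbers, with compound 2 within the scatter of it and compound 1 far beyond it. The unmeasured compound 4 `O=S(=O)(c1ccccc1)c1cnc2ccccc2c1N1CCCCC1` differs from compound 3 in one place only: piperidin-1-yl in place of pyrrolidin-1-yl on an aromatic carbon. Going by the values given here, the single measured step that also swaps the ring on this carbon, a number 5.4 percentage points higher from compound 2 to compound 3 (within the scatter), stayed within the scatter, so a step of similar smallness and of no clear direction is expected here as well. The expected step of a number 2.9 percentage points higher from compound 3 to compound 4 (within the scatter) leaves compound 4 estimated at 10%, within a range from 0% to 35%.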

Compound 4, a percentage reported as inhibition, at one concentration (the size of the read-out at that concentration, not a potency): 71.4%
For compound 4 the middle estimate is 61.4 percentage points below the measured one, outside the stated range (above it).
By their numbers in this assay, from the lowest: compounds 2 and 3 (each within the scatter of the next); then compound 4; then compound 1.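

Piperidin-1-yl in place of pyrrolidin-1-yl gives a number 64.3 percentage points higher from compound 3 to compound 4 (beyond the scatter) in this assay, so this position responds strongly to the ring it carries, which compounds 2 and 3 alone did not reveal. Piperidin-1-yl in place of 4-ethylpiperazin-1-yl gives a number 69.7 percentage points higher from compound 2 to compound 4 (beyond the scatter), so of these three rings only piperidin-1-yl gives a high number. Nothing available here explains why these rings differ so sharply.

Still open, from the compounds shown here alone, is whether a morpholine ring or a seven-membered azepane ring on this carbon would keep the number high. Also open, going by these compounds, is how the ring on this carbon combines with chlorine or fluorine elsewhere on the shared core.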